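A few compounds are considered here, and "the series" means these few. Any claim that something is new, unique, unknown or untested is made for them only; others in the source may bear on it.

Compound 1 `CCCCN(C)c1nc(C(F)(F)F)ccc1CNC(=O)C(C)c1ccc(NS(C)(=O)=O)c(F)c1`: 0.8 nM
Compound 2 `CC(C(=O)NCc1ccc(C(F)(F)F)nc1N1CCC(C(=O)c2ccc(F)cc2)CC1)c1ccc(NS(C)(=O)=O)c(F)c1`: 3.9 nM

Both are read in a functional assay on CHO-K1 cells for antagonist activity at transient receptor potential cation channel subfamily V member 1 (Homo sapiens), read by FLIPR; on this read-out lower numbers stand for stronger inhibition and higher numbers for weaker inhibition. Of the two numbers, compound 2 gives the higher one, and the gap to compound 1 lies beyond the scatter. Compound 3 `COC1CCN(c2nc(C(F)(F)F)ccc2CNC(=O)C(C)c2ccc(NS(C)(=O)=O)c(F)c2)CC1` is not yet measured. It differs from compound 2 by methoxy in place of (4-fluorophenyl)carbonyl on a saturated ring carbon. For the measured compounds named here, no measured step of this kind exists, so the direction rests only on the two values shown. A modest move toward a lower number is expected, possibly not beyond the scatter. Compound 3 is expected to give 2 nM, with a range from 0.6 nM to 6.5 nM. The expected step is a 2.0-fold lower number from compound 2 to compound 3 (0.29 log units; within the scatter).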

Compound 3, inhibition constant: 2.4 nM
Compound 3: middle estimate off by 1.2-fold (0.08 log units), on the low side; low and high end bracket the measured number.
By their numbers in this assay, from the lowest: compound 1; then compounds 3 and 2 (each within the scatter of the next).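

On the saturated ring carbon, methoxy in place of (4-fluorophenyl)carbonyl gives a 1.6-fold lower number from compound 2 to compound 3 (0.21 log units; within the scatter) in this assay, so removing 9 heavy atoms and the aromatic ring while adding 2 heavy atoms leaves the two values within the scatter. On the aromatic carbon, 4-methoxypiperidin-1-yl in place of butyl(methyl)amino gives a 3.0-fold higher number from compound 1 to compound 3 (0.48 log units; beyond the scatter), and compound 1 keeps the lowest number. Nothing at hand explains either step. On these data alone, whether a hydroxyl or an amine on the saturated ring carbon would read alike remains open. Also open, as far as these compounds go, is whether the gap to compound 1 follows from the ring itself or from loss of the butyl chain.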